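Adding trifluoromethyl to the benzyl group of compound 1

This account rests on a few compounds, and the source may have more. Where it says the series, first, only, none or still open, it means among the compounds named here.

In an ADME assay on GES1 cells (Homo sapiens) for inhibition, read by MTT assay, with a stated time of 72 h (on this read-out lower numbers stand for stronger inhibition and higher numbers for weaker inhibition), three compounds have been measured so far. Compound 1 `Cc1cc(Nc2ccn(Cc3ccccc3)n2)n2nc(SCc3ccc(Br)cc3)nc2n1` gives 44400 nM, and compound 2 `Cc1cc(Nc2cc(-c3ccc(F)cc3)[nH]n2)n2nc(SCc3ccc(Br)cc3)nc2n1` gives 34200 nM. Among the compounds with values here, these two numbers lie within the scatter of each other, so compound 1 stands level with the only other compound that has a number. Compound 3 `Cc1cc(Nc2cc(-c3ccccc3)[nH]n2)n2ncnc2n1` is reported as > 50000 nM, which is a limit of the assay and not a number.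

The next compound is compound 4 `Cc1cc(Nc2ccn(Cc3ccc(C(F)(F)F)cc3)n2)n2nc(SCc3ccc(Br)cc3)nc2n1`, in which the benzyl of compound 1 becomes 4-(trifluoromethyl)benzyl: trifluoromethyl in place of hydrogen on an aromatic carbon. Trifluoromethyl takes the place of hydrogen on an aromatic carbon, para to a large group. Within the data shown here, no measured pair differs in one place only, so the data give no direct guide to this change. Compound 2 has a different group at this end of the molecule, yet its 34200 nM stays within the scatter of compound 1. The step of a 1.3-fold lower number from compound 1 to compound 4 (0.10 log units; within the scatter) is therefore expected to stay within the scatter. The estimated value for compound 4 is 35000 nM, with an expected range from 15000 nM to 50000 nM.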

Compound 4, half-maximal inhibitory concentration: 30200 nM
The estimate for compound 4 lay 1.2-fold (0.06 log units) above the measured number, within the range that was stated.
By their numbers in this assay, from the lowest: compounds 4, 2 and 1 (each within the scatter of the next). At a limit, above all of these: compound 3.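

In this assay, within the data shown here, the pair gives the first direct reading of a single change: trifluoromethyl in place of hydrogen on an aromatic carbon, para to a large group, gives a 1.5-fold lower number from compound 1 to compound 4 (0.17 log units; within the scatter). The benzyl group of compound 1 therefore accepts these four added heavy atoms at this place with the two compounds standing level. The earlier compounds shown here differ from each other in more than one place, so they could not show this.

Going by these compounds, it remains open whether an amine, a carboxylic acid or a longer chain at this same place would also stay within the scatter, since one step speaks only for trifluoromethyl. Any step towards weaker inhibition would also meet the upper end of the read-out: the limit of > 50000 nM in this assay, at which 1 of the 4 values shown sits.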